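The source may hold more compounds than are shown below. What is called first, only, known or untested is meant among the compounds shown, and "the series" means these compounds.

Measured in a functional assay on brain (Rattus norvegicus, strain Wistar) for inhibition; on this read-out higher numbers stand for weaker inhibition and lower numbers for stronger inhibition
- compound 1 `COc1ccc(-c2c(C)[nH]c(=O)n2C)cc1` gives 147000 nM
- compound 2 `Cc1[nH]c(=O)n(C)c1-c1ccc(C(C)(C)C)cc1` gives 8400 nM

Compound 2 holds the lower of the two numbers, which makes it the stronger inhibitor of the pair. Compound 3 `CCCCCc1ccc(-c2c(C)[nH]c(=O)n2C)cc1` differs from it in one group: pentyl in place of tert-butyl on an aromatic carbon. For the measured compounds named here, the one measured step at this aromatic carbon is large, an 18-fold lower number from compound 1 to compound 2 (1.24 log units; beyond the scatter), but it swapped methoxy for tert-butyl, and no measured step compares two carbon-only chains. In this assay only a small step is therefore expected, with no firm direction. The expected change is a 1.2-fold lower number from compound 2 to compound 3 (0.08 log units; within the scatter), which would not go beyond the scatter. For compound 3 the estimate is 7000 nM, with an expected range of 2000 nM to 25000 nM.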

Compound 3, half-maximal inhibitory concentration: 5900 nM
Compound 3: the middle estimate sits 1.2-fold (0.07 log units) above what was measured; the measured number falls inside the stated range.
By their numbers in this assay, from the lowest: compounds 3 and 2 (each within the scatter of the next); then compound 1.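

In this assay, pentyl in place of tert-butyl gives a 1.4-fold lower number from compound 2 to compound 3 (0.15 log units; within the scatter) and so, at this aromatic carbon, these two carbon-only groups cannot be told apart. Set against methoxy, pentyl gives a 25-fold lower number from compound 1 to compound 3 (1.40 log units; beyond the scatter) and so matches the large step seen with tert-butyl, which shows that this step does not depend on tert-butyl alone. Nothing measured here explains these numbers.

Still open, as far as these compounds go, is whether a longer chain such as octyl, a smaller group such as methyl, or an amine at this carbon would give a number like those of the two carbon-only groups or like that of methoxy.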